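This account rests on a few compounds, and the source may have more. Where it says the series, first, only, none or still open, it means among the compounds named here.

Measured so far:
Compound 1, `O=C(O)CSc1nnc(Br)n1Cc1ccc(Br)c2ccccc12`: 94 nM
Compound 2, `O=S(=O)(CSc1nnc(Br)n1Cc1ccc(Br)c2ccccc12)Nc1cncc(C(F)(F)F)c1`: 6380 nM

In an assay on HEK293 cells for inhibition of solute carrier family 22 member 12 (Homo sapiens) (a higher number here means a weaker inhibitor, a lower number a stronger inhibitor), compound 1 gives 94 nM, and compound 2 gives 6380 nM. Among the measured compounds shown here, of the two numbers known, compound 2 stands highest, that is, it is the weaker inhibitor; the gap between it and compound 1 is far beyond the usual scatter, so the two compounds are clearly different in this assay. For the measured compounds named here, compound 1 carries a carboxylic acid on its shared core, while compound 2 carries a sulfonamide in its place, but as no single-step pair between them has been worked out, only their two values can be compared.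

Compound 3, `COc1ncccc1NS(=O)(=O)CSc1nnc(Br)n1Cc1ccc(Br)c2ccccc12`, keeps the sulfonamide of compound 2 and changes the aromatic ring on its nitrogen:

2-methoxypyridin-3-yl in place of 5-(trifluoromethyl)pyridin-3-yl on a sulfonamide nitrogen

Going by the values given here, no measured pair shows what such a swap does in this assay, so the expectation rests on compound 2 alone. The expected step of a 1.3-fold lower number from compound 2 to compound 3 (0.11 log units; within the scatter) is small, within the scatter, with no clear direction. Compound 3 is therefore estimated at about 5000 nM, most likely between 1500 nM and 16000 nM.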

Compound 3, half-maximal inhibitory concentration: 4050 nM
For compound 3 the middle estimate is 1.2-fold (0.09 log units) above the measured one; low and high end bracket the measured number.
By their numbers in this assay, from the lowest: compound 1; then compounds 3 and 2 (each within the scatter of the next).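

Among the compounds shown here, this is the first measured step at the sulfonamide nitrogen. In this assay, 2-methoxypyridin-3-yl in place of 5-(trifluoromethyl)pyridin-3-yl gives a 1.6-fold lower number from compound 2 to compound 3 (0.20 log units; within the scatter), so this pair cannot be told apart, even though the ring carries a different group and the group's name gives it a different number on the ring. For this one pair, then, the assay does not distinguish a pyridine ring bearing methoxy from one bearing trifluoromethyl at this position, and no measurement at hand offers an explanation for that.

On these data alone, it remains open whether the same holds for quite different groups on the sulfonamide nitrogen, such as a plain phenyl ring, a methyl group or a longer alkyl chain, since two pyridine rings alone say little about the range this position accepts. This single pair also cannot show whether the change of group and the change of its number on the ring would each leave the value alone, or whether they would shift it in opposite directions and cancel out when made together.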